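The source may report more compounds than this note shows. Statements on the series, on what has been measured and on what is new or still open speak of the compounds shown alone.

Two compounds share one core. Compound 1 `CCOC(=O)C1=Cc2ccccc2OC1(OCc1cn(-c2ccccc2)nn1)C(F)(F)F` carries phenyl on an aromatic nitrogen, and in a functional assay on HeLa cells (Homo sapiens) for inhibition, read by MTT assay, with a stated time of 24 h (on this read-out lower numbers stand for stronger inhibition and higher numbers for weaker inhibition), compound 1 reaches only the limit > 150000 nM. Going by the values given here, compound 2 `CCOC(=O)C1=Cc2ccccc2OC1(OCc1cn(CC(=O)Nc2ccc(OC)cc2)nn1)C(F)(F)F` gives 31900 nM in this assay, the only plain number measured here. The step of an at least 4.7-fold lower number from compound 1 to compound 2 (0.67 log units; beyond the scatter) shows that the group on that nitrogen matters, with the starting point resting at the limit of > 150000 nM in this assay, at which 1 of the 2 values shown sits. Compound 3 `CCOC(=O)C1=Cc2ccccc2OC1(OCc1cn(-c2cccc(OC)c2)nn1)C(F)(F)F` differs from compound 2 by 3-methoxyphenyl in place of ((4-methoxyphenyl)carbamoyl)methyl on an aromatic nitrogen. Among the compounds with values here, this puts an aryl group back on the ring nitrogen, as in compound 1, so the one measured step that bears on it points toward weaker inhibition. Compound 3 is therefore expected to show a step of a 3.1-fold higher number from compound 2 to compound 3 (0.50 log units; beyond the scatter) toward a higher number. The estimate for compound 3 is 100000 nM, within 30000 nM to 300000 nM, with a real chance that only a limit is reached.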

Compound 3, half-maximal inhibitory concentration: > 150000 nM
Compound 3: a limit, no number; the forecaster's own chance of this, stated with the estimate: 45%; middle value at least 1.5-fold (0.17 log units) from the limit.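

Putting 3-methoxyphenyl in place of ((4-methoxyphenyl)carbamoyl)methyl on the aromatic nitrogen brings an at least 4.7-fold higher number from compound 2 to compound 3 (0.67 log units; beyond the scatter), so a methoxy group on an aryl ring set directly on that nitrogen does not restore what compound 2 shows. Compound 3 reaches only a limit in this assay, not a number, and the step between compound 1 and compound 3 joins two limits and cannot be read. Of the compounds shown, only compound 2 gives a plain number, and the other two stay at one limit: the limit of > 150000 nM in this assay, at which 2 of the 3 values shown sit.

The compounds shown leave open which part of ((4-methoxyphenyl)carbamoyl)methyl carries the difference, the amide or the 4-methoxyphenyl ring. They also leave open whether a benzyl group, or a chain ending in a carboxylic acid, on that nitrogen would give a plain number.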